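Cytotoxicity notes on the shared core: tert-butyl to methylsulfanyl

The compounds below may be only part of what the source reports. "The series", "measured", "known", "first", "only" and "open" are said of these compounds alone.

Measured so far in an ADME assay on THP-1 cells (Homo sapiens) for cytotoxicity, read by resazurin assay, with a stated time of 72 h; a higher number here means that more compound is tolerated, a lower number that less compound is tolerated:
compound 1, `Cc1cccc(C(=O)/C=C/c2ccc([N+](=O)[O-])o2)c1`: 42100 nM
compound 2, `CC(C)(C)c1ccc(C(=O)/C=C/c2ccc([N+](=O)[O-])o2)cc1`: > 50000 nM
compound 3, `O=C(/C=C/c1ccc([N+](=O)[O-])cc1)c1ccc(N2CCCCC2)cc1`: > 50000 nM.

The value of compound 2 in this assay is a limit of the assay, not a number. The value of compound 3 in this assay is likewise a limit. Compound 1 alone returns a numeric reading, and it falls close to the other two. Compound 2 therefore stands at the upper edge of what is reported here: the limit of > 50000 nM in this assay, at which 2 of the 3 values shown sit, covers two of the three results, and compound 2 is one of them. Among the measured compounds shown here, no step between measured compounds that differ in one place is available, so nothing measured tells how a single change on the aromatic carbon moves this read-out.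

Compound 4, `CSc1ccc(C(=O)/C=C/c2ccc([N+](=O)[O-])o2)cc1`, remains to be measured in this assay. Its difference from compound 2 is methylsulfanyl in place of tert-butyl on an aromatic carbon. With compound 2 sitting at a limit and all three results close together, the step of an at least 1.1-fold lower number from compound 2 to compound 4 (0.04 log units; that floor lies within the scatter) is expected to be none beyond the scatter, and a further limit is the more likely outcome. Compound 4 is accordingly expected at 45000 nM, within a range from 20000 nM to 100000 nM.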

Compound 4, half-maximal cytotoxic concentration: 13100 nM
For compound 4 the middle estimate is 3.4-fold (0.54 log units) above the measured one; measured number outside the range, below it.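

In this assay, methylsulfanyl in place of tert-butyl on an aromatic carbon gives an at least 3.8-fold lower number from compound 2 to compound 4 (0.58 log units; beyond the scatter). Among the compounds shown here, this is the first single-place step, and it shows that this position can move the read-out beyond the scatter, towards less compound being tolerated. Its size is only a floor, because the reading for compound 2 is a limit of the assay and not a number: the limit of > 50000 nM in this assay, at which 2 of the 4 values shown sit.

One pair cannot separate the loss of tert-butyl from the arrival of methylsulfanyl, so the step belongs to the exchange as a whole and not to either group alone. From the compounds shown here alone, whether methoxy, an amine or a carboxylic acid on the same aromatic carbon would lower the number in the same way remains open, as does whether the exchange would behave alike on the core of compound 3.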